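Thiazolidinone series: paw edema inhibition, phenyl to 4-chlorobenzyl

A few compounds are considered here, and "the series" means these few. Any claim that something is new, unique, unknown or untested is made for them only; others in the source may bear on it.

Measured so far:
- compound 1, `Cc1ccc(N2C(=O)CSC2c2sc(Cc3ccc(Cl)cc3)nc2C)cc1`: 81.3%
- compound 2, `COc1ccc(N2C(=O)CSC2c2sc(-c3ccccc3)nc2C)cc1`: 67.1%

Both numbers come from a functional assay on the whole organism (strain Wistar albino) for inhibition, with Rattus norvegicus as the target, read by paw edema, with stated times of 1 h and 4 h, at a dose of 40 mg/kg by the oral route; a higher number here means more inhibition at the dose given (going by the name of the read-out), a lower number less inhibition. Compound 2 stands lowest of the two numbers; its nearest neighbour is compound 1, which lies higher by a margin beyond the usual scatter. The two compounds differ in more than one place, so their values are noted side by side without reading a single step out of them.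

Compound 3, `COc1ccc(N2C(=O)CSC2c2sc(Cc3ccc(Cl)cc3)nc2C)cc1`, has not yet been measured in this assay. It is derived from compound 2 by one change: 4-chlorobenzyl in place of phenyl on an aromatic carbon. The group entering is the same one carried by compound 1, which gave 81.3% in this assay.

Expectation: the step from compound 2 to compound 3 is estimated to be upward and beyond the scatter, a number 9.9 percentage points higher from compound 2 to compound 3 (within the scatter), because compound 1 with the same entering group gives 81.3%. For compound 3 the estimated result in this assay is 77%, with a range from 65% to 88%.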

Compound 3, a percentage reported as inhibition, in the whole organism at one dose (the size of the read-out at that dose, not a potency): 55.9%
For compound 3 the middle estimate is 21.1 percentage points above the measured one; measured number outside the range, below it.
By their numbers in this assay, from the lowest: compound 3; then compound 2; then compound 1.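

In this assay, 4-chlorobenzyl in place of phenyl on the aromatic carbon of the five-membered aromatic ring with 1 nitrogen and 1 sulfur gives a number 11.2 percentage points lower from compound 2 to compound 3 (beyond the scatter), so this group does not bring a high reading with it when methoxy is present on the other aromatic ring. With 4-chlorobenzyl held fixed, methoxy in place of methyl gives a number 25.4 percentage points lower from compound 1 to compound 3 (beyond the scatter), which ties the high reading of compound 1 to 4-chlorobenzyl and methyl together rather than to 4-chlorobenzyl alone, at least within these three compounds. No measurement at hand accounts for either step.

For the compounds shown here, whether the change from phenyl to 4-chlorobenzyl would keep its downward direction with methyl in place of methoxy remains open, since the only step read at this position has methoxy on the other ring. Also open, on these data alone, is how a dimethylamino group or a carboxylic acid in place of methoxy, or a longer chain such as 2-phenylethyl in place of 4-chlorobenzyl, would read at this single dose.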